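Chloro for fluoro on a weakly active compound

The compounds below may be only part of what the source reports. "The series", "measured", "known", "first", "only" and "open" are said of these compounds alone.

In a functional assay on U-373MG ATCC cells (Homo sapiens) for inhibition, read by MTT assay, with a stated time of 72 h (on this read-out lower numbers stand for stronger inhibition and higher numbers for weaker inhibition), compound 1 (`CC1(C)CC(NC(=S)NCc2ccccc2)c2cc(F)ccc2O1`) gives 27000 nM and compound 3 (`CC1(C)CC(NC(=O)NCc2ccccc2)c2cc(Br)ccc2O1`) gives 27000 nM on the same read-out. Compound 2 (`CC1(C)CC(NC(=O)Nc2ccccc2Cl)c2cc(F)ccc2O1`) stands at 40000 nM within the usual scatter of both others, so these numbers set no order among the three.

Compound 4 (`CC1(C)CC(NC(=O)Nc2ccccc2Cl)c2cc(Cl)ccc2O1`) has not yet been measured. Compared with compound 2, it carries chloro in place of fluoro on an aromatic carbon and is otherwise unchanged. For the measured compounds named here, no measured pair differs in only one place, so the data do not show the size of such a change directly. Compound 2 at 40000 nM and compound 3 at 27000 nM lie within the scatter of each other even though they differ in more than one place, which gives no ground to expect a large move. The expected step of a 1.3-fold lower number from compound 2 to compound 4 (0.10 log units; within the scatter) is therefore none beyond the scatter, with no firm direction. In this assay compound 4 is estimated at 32000 nM with an expected range from 15000 nM to 60000 nM for repeated measurements.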

Compound 4, half-maximal inhibitory concentration: 17000 nM
The estimate for compound 4 lay 1.9-fold (0.27 log units) above the measured number, within the range that was stated.
By their numbers in this assay, from the lowest: compounds 4, 1, 3 and 2 (each within the scatter of the next, the first and the last beyond it).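

In this assay, chloro in place of fluoro on an aromatic carbon gives the first comparison among these compounds that differs in only one place, and the number falls by a modest step beyond the usual scatter (a 2.4-fold lower number from compound 2 to compound 4 (0.37 log units; beyond the scatter)). The position, meta to a fused ring and para to a fused ring, therefore does not treat these two groups alike, at least with the rest of compound 2 unchanged. No measurement at hand accounts for the step.

The compounds shown leave open whether the same exchange would give a similar step on the core of compound 1, which carries a different side chain. They also do not show how this position would respond to a group of another kind, such as a methoxy group, an amine or a carboxylic acid.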